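A few compounds are considered here, and "the series" means these few. Any claim that something is new, unique, unknown or untested is made for them only; others in the source may bear on it.

Compound 1 `O=C(/C(=C\c1ccc(O)c([N+](=O)[O-])c1)SCc1ccc(Br)cc1)C1CCNC1` — > 100000 nM
Compound 2 `O=C(/C(=C\c1ccc(Cl)cc1)Sc1ccc(Cl)cc1)c1ccc(Cl)cc1` — 1000 nM
Compound 3 `CCOc1ccc(/C=C(/Sc2ccccc2Cl)C(=O)c2ccc(Cl)cc2)cc1OC` — 50000 nM

All three compounds share a core in which a carbonyl carbon is joined to a double-bonded chain carbon that carries a sulfur-linked group and a substituted aromatic ring. They were tested in a functional assay on DU-145 cells (Homo sapiens) for inhibition, read by trypan blue exclusion, with a stated time of 96 h; a lower number here means a stronger inhibitor of growth, a higher number a weaker inhibitor of growth. In this assay compound 1 gives > 100000 nM, which is a limit of the assay and not a number. Compound 2 gives 1000 nM in this assay. Compound 3 gives 50000 nM in this assay. Both compound 2 and compound 3 carry a six-membered aromatic ring of carbon only on the carbonyl carbon, where compound 1 carries a pyrrolidin-3-yl.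

Compound 1 stands at the edge of what the assay can report: the limit of > 100000 nM in this assay, at which 1 of the 3 values shown sits.

Compound 4 `O=C(/C(=C\c1ccc(O)c([N+](=O)[O-])c1)SCc1ccc(Br)cc1)c1ccc(Br)cc1` has not yet been measured. It differs from compound 1 in one place: 4-bromophenyl in place of pyrrolidin-3-yl on a carbonyl carbon.

With an aromatic ring on the carbonyl carbon, compound 2 gives 1000 nM in this assay, and compound 3 gives 50000 nM. Because compound 2 gives 1000 nM and compound 3 gives 50000 nM, compound 4 is expected to give a number that the assay can report. The expected step of an at least 5.0-fold lower number from compound 1 to compound 4 (0.69 log units; beyond the scatter) runs downward, beyond the usual scatter. Compound 4 is estimated at about 20000 nM, with a range from 3000 nM to 100000 nM.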

Compound 4, concentration for 50% growth inhibition: 10000 nM
Compound 4: the middle estimate sits 2.0-fold (0.30 log units) above what was measured; the range from low to high includes it.
By their numbers in this assay, from the lowest: compound 2; then compound 4; then compound 3. At a limit, above all of these: compound 1.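

In this assay, changing only the group on the carbonyl carbon and leaving the rest of the molecule untouched gives an at least 10-fold lower number from compound 1 to compound 4 (1.00 log units; beyond the scatter). Compound 1 stands at a limit of the assay and not at a number, so this step gives only a minimum size, and the true gap could be larger: the limit of > 100000 nM in this assay, at which 1 of the 4 values shown sits. Compound 2 and compound 3 differ from compound 1 in several places at once, so they could only hint at the role of this position, whereas this pair ties the change to it directly: 4-bromophenyl in place of pyrrolidin-3-yl on a carbonyl carbon is enough on its own to bring the compound into the range the assay can report.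

The compounds shown leave open whether this gain needs the bromine or whether an unsubstituted phenyl on the carbonyl carbon would serve as well. They also do not show how a group of a different kind at this place, such as an open-chain amine or a carboxylic acid, would read in this assay.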